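Working notes: varying the group on the aromatic oxygen

The compounds below may be only part of what the source reports. "The series", "measured", "known", "first", "only" and "open" are said of these compounds alone.

Measured in a functional assay on U-937 cells (Homo sapiens) for cytotoxicity, read by MTT assay, with a stated time of 24 h; on this read-out higher numbers stand for weaker inhibition and lower numbers for stronger inhibition: compound 1 `CC(=O)Oc1c(Br)cc(Br)cc1Oc1ccc(Br)cc1Br` gives 32.3 ug/mL; compound 2 `CC(C)(C)C(=O)C(C#N)Oc1c(Br)cc(Br)cc1Oc1ccc(Br)cc1Br` gives 32.5 ug/mL.

Within the data shown here, compound 2 stands at one of two numbers that the scatter does not separate; the only measured step, a 1.0-fold higher number from compound 1 to compound 2 (0.00 log units; within the scatter), exchanged the group on the same aromatic oxygen and moved nothing beyond the scatter.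

Compound 3 `C#CCOc1c(Br)cc(Br)cc1Oc1ccc(Br)cc1Br` differs from compound 2 in one place: propargyl in place of cyano((tert-butyl)carbonyl)methyl on an oxygen on an aromatic ring. The step bearing on this change is a 1.0-fold higher number from compound 1 to compound 2 (0.00 log units; within the scatter), which altered the same position with a larger group and gave no shift. The present change again touches only the group on that oxygen, so the expected step is a 1.0-fold lower number from compound 2 to compound 3 (0.01 log units; within the scatter), that is none beyond the scatter.

Compound 3 is therefore estimated at 32 ug/mL, with a range of 16 ug/mL to 65 ug/mL.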

Compound 3, half-maximal inhibitory concentration: 29.5 ug/mL
For compound 3 the middle estimate is 1.1-fold (0.04 log units) above the measured one, within the range that was stated.
By their numbers in this assay, from the lowest: compounds 3, 1 and 2 (each within the scatter of the next).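

With the group on the oxygen on an aromatic ring cut from cyano((tert-butyl)carbonyl)methyl to propargyl, a change from 9 heavy atoms to 3 and from 2 hydrogen-bond acceptors to 0, this assay gives a 1.1-fold lower number from compound 2 to compound 3 (0.04 log units; within the scatter). Replacing acetyl with the same propargyl gives a 1.1-fold lower number from compound 1 to compound 3 (0.04 log units; within the scatter), so three groups of different size, with and without a carbonyl, are not separated at this position. No measured evidence bears on why this position shows so little response.

The compounds shown leave open whether an amine or a carboxylic acid on this oxygen would move the number beyond the scatter. They also leave open whether a change elsewhere on the shared core would do so.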